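The source may report more compounds than this note shows. Statements on the series, on what has been measured and on what is new or still open speak of the compounds shown alone.

Measured compounds:
compound 1, `CCN(CC)c1ccc2cc(C(=O)c3ccc(N4CCN(C(=O)CN5CCN(C(=O)/C=C/c6ccccc6)CC5)CC4)cc3)oc2c1`, 13400 nM
compound 2, `CCN(CC)c1ccc2cc(C(=O)c3ccc(N4CCN(C(=O)CN5CCN(S(=O)(=O)c6ccc(F)cc6)CC5)CC4)cc3)oc2c1`, 20500 nM
compound 3, `CCN(CC)c1ccc2cc(C(=O)c3ccc(N4CCN(C(=O)CN5CCN(Cc6ccc(/C=C/C(=O)OC)cc6)CC5)CC4)cc3)oc2c1`, 8730 nM

These three share one core and differ only in the group carried on an amine nitrogen in a ring at the far end of the molecule. In a functional assay on MCF7 cells (Homo sapiens) for cytotoxicity, read by MTT assay, with a stated time of 48 h (on this read-out lower numbers stand for stronger inhibition and higher numbers for weaker inhibition), compound 1 gives 13400 nM, the second highest of the three numbers; compound 2 gives 20500 nM and compound 3 gives 8730 nM, and both of these lie within the scatter of compound 1. Within the data shown here, the single step measured here, a 1.5-fold higher number from compound 1 to compound 2 (0.18 log units; within the scatter), exchanges the (2-phenylethenyl)carbonyl for a (4-fluorophenyl)sulfonyl and lands within the scatter.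

Compound 4, `CCN(CC)c1ccc2cc(C(=O)c3ccc(N4CCN(C(=O)CN5CCN(Cc6ccc(C(F)(F)F)cc6)CC5)CC4)cc3)oc2c1`, is not yet measured. It differs from compound 1 in that (4-(trifluoromethyl)benzyl in place of (2-phenylethenyl)carbonyl on an amine nitrogen in a ring). Compound 3 also carries a benzyl group in that same place, and its value sits within the scatter of compound 1, so for compound 4 no step beyond the scatter is expected in this assay. Compound 4 is therefore expected to give 9500 nM, within a range from 4000 nM to 22000 nM. The expected step of a 1.4-fold lower number from compound 1 to compound 4 (0.15 log units; within the scatter) is estimated to stay within the usual scatter of repeated measurements.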

Compound 4, half-maximal inhibitory concentration: 18200 nM
The estimate for compound 4 lay 1.9-fold (0.28 log units) below the measured number; low and high end bracket the measured number.
By their numbers in this assay, from the lowest: compounds 3, 1, 4 and 2 (each within the scatter of the next, the first and the last beyond it).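

In this assay, 4-(trifluoromethyl)benzyl on the amine nitrogen in a ring stays within the scatter of both (2-phenylethenyl)carbonyl (a 1.4-fold higher number from compound 1 to compound 4 (0.13 log units; within the scatter)) and (4-fluorophenyl)sulfonyl (a 1.1-fold lower number from compound 2 to compound 4 (0.05 log units; within the scatter)), so neither exchange at this nitrogen gives a clear change in the number. The new information comes from comparing the two benzyl compounds: replacing 2-(methoxycarbonyl)ethenyl on an aromatic carbon with trifluoromethyl gives a 2.1-fold higher number from compound 3 to compound 4 (0.32 log units; beyond the scatter), a modest step but the first one shown to lie beyond the scatter, and so the outer substituent on the benzyl ring can shift the number even though the exchanges at the nitrogen above do not. No measurement shown here accounts for this step.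

As far as these compounds go, whether an amine or a carboxylic acid on that aromatic carbon would move the number further, in either direction, remains open. A plain benzyl group with no added substituent would also be informative, as it would show how much each of these two substituents contributes on its own.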